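The source may hold more compounds than are shown below. What is called first, only, known or untested is meant among the compounds shown, and "the series" means these compounds.

In an assay on cells with melanin-concentrating hormone receptor 1 (Homo sapiens) as the target, read by radioligand binding (a lower number here means a stronger inhibitor, a higher number a weaker inhibitor), compound 3 `CC(C)C(C)Oc1cccc2ccc(N)nc12` gives 199 nM, the highest of the two numbers recorded, with compound 1 `Nc1ccc2cccc(OCC3CCCC3)c2n1` at 53 nM as its nearest neighbour. Compound 2 `CSCCOc1cccc2ccc(N)nc12` reaches only the limit of this assay, > 2000 nM. Compound 4 `Nc1ccc2cccc(OCC3CCOC3)c2n1` carries (oxolan-3-yl)methyl in place of 1,2-dimethylpropyl on an oxygen on an aromatic ring. Among the compounds with values here, two measured steps bear on this: a 3.8-fold higher number from compound 1 to compound 3 (0.57 log units; beyond the scatter), and an at least 37-fold higher number from compound 1 to compound 2 (1.57 log units; beyond the scatter), where a chain carrying a hetero atom replaced the cyclopentyl ring (the limit of > 2000 nM in this assay, at which 1 of the 3 values shown sits). The entering group is a ring like that of compound 1, yet with an oxygen in it, so the two precedents pull in opposite directions; roughly no change beyond the scatter is expected, a 1.3-fold higher number from compound 3 to compound 4 (0.10 log units; within the scatter). Compound 4 is therefore estimated at 250 nM, between 60 nM and 1000 nM.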

Compound 4, half-maximal inhibitory concentration: 115 nM
Compound 4: the middle estimate sits 2.2-fold (0.34 log units) above what was measured; the range from low to high includes it.
By their numbers in this assay, from the lowest: compound 1; then compounds 4 and 3 (each within the scatter of the next). At a limit, above all of these: compound 2.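

On the oxygen on an aromatic ring, (oxolan-3-yl)methyl and 1,2-dimethylpropyl cannot be told apart in this assay, with a 1.7-fold lower number from compound 3 to compound 4 (0.24 log units; within the scatter). Placing an oxygen in the cyclopentyl ring of compound 1 gives a modest loss, with a 2.2-fold higher number from compound 1 to compound 4 (0.34 log units; beyond the scatter). The oxygen-bearing ring stays far from the open sulfur chain, with an at least 17-fold lower number from compound 2 to compound 4 (1.24 log units; beyond the scatter), and this step is read from a limit: the limit of > 2000 nM in this assay, at which 1 of the 4 values shown sits.

From the compounds shown here alone, whether a ring nitrogen, as in pyrrolidin-3-ylmethyl, would give a similar number remains open. So does the effect of a six-membered ring with oxygen, such as (oxan-4-yl)methyl.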